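The compounds below may be only part of what the source reports. "The series", "measured", "known", "first", "only" and "open" are said of these compounds alone.

Measured compounds: compound 1 `CCCNc1nc(NCc2ccc(NC(=O)c3ccc(F)cc3)cc2)c2ccccc2n1` gives 1700 nM in a functional assay on HCT-116 cells (Homo sapiens) for inhibition, read by luminescence and resazurin assay, with a stated time of 3 days; a lower number here means a stronger inhibitor, a higher number a weaker inhibitor; compound 2 `CNc1nc(NCc2ccc(NC(=O)c3ccc(F)cc3)cc2Cl)c2ccccc2n1` gives 2000 nM; compound 3 `CN(C)CCCNc1nc(NCc2ccc(NC(=O)c3ccc(F)cc3)cc2)c2ccccc2n1` gives 10000 nM.

Compound 3 stands at the highest number of the three, beyond the scatter from both neighbours. Compound 4 `CNc1nc(NCc2ccc(NC(=O)c3ccc(F)cc3)cc2)c2ccccc2n1` has not been measured; it differs from compound 3 by hydrogen in place of 2-(dimethylamino)ethyl on a saturated chain carbon bound to a nitrogen on an aromatic ring. For the measured compounds named here, the one measured step that bears on this change is a 5.9-fold higher number from compound 1 to compound 3 (0.77 log units; beyond the scatter), which runs the opposite way, adding the dimethylamino group to a chain carbon. Compound 2, which carries a methylamino group on the shared core, and compound 1 sit close to each other on the numbers, and compound 4 shares that methylamino group. The account therefore expects compound 4 to return roughly to where compound 1 and compound 2 stand, a step of about a 5.6-fold lower number from compound 3 to compound 4 (0.74 log units; beyond the scatter) in this assay. Compound 4 is estimated at 1800 nM, with a range from 700 nM to 5000 nM.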

Compound 4, half-maximal inhibitory concentration: 1600 nM
Estimate against measurement, compound 4: 1.1-fold (0.05 log units) above; the measured number falls inside the stated range.
By their numbers in this assay, from the lowest: compounds 4, 1 and 2 (each within the scatter of the next); then compound 3.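

In this assay, hydrogen in place of 2-(dimethylamino)ethyl gives a 6.3-fold lower number from compound 3 to compound 4 (0.80 log units; beyond the scatter), so the higher number of compound 3 now shows up against a second neighbour, one carrying the methylamino group. The other two steps separate nothing: hydrogen in place of ethyl gives a 1.1-fold lower number from compound 1 to compound 4 (0.03 log units; within the scatter) and hydrogen in place of chloro on an aromatic carbon gives a 1.3-fold lower number from compound 2 to compound 4 (0.10 log units; within the scatter), which leaves compound 3 as the only one of the four that stands apart. Nothing available explains the step from compound 3 to compound 4.

Still open, from the compounds shown here alone, is whether a hydroxyl group or a morpholine in place of the dimethylamino group would give a step of the same size. Also open, going by these compounds, is whether chloro on that aromatic carbon would read the same on compound 3.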